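Cytotoxicity of biaryl amide acids in BJ cells

The source may hold more compounds than are shown below. What is called first, only, known or untested is meant among the compounds shown, and "the series" means these compounds.

Measured so far:
compound 1 `CC(C)N(Cc1cccc(OCCCCCC(=O)O)c1)C(=O)c1ccc(-c2cccc(N(C)C)c2)cc1` — > 26000 nM
compound 2 `CC(C)N(Cc1cccc(OCCCCCC(=O)O)c1)C(=O)c1ccc(-c2ccsc2)cc1` — > 26000 nM

In an ADME assay on BJ cells (Homo sapiens) for cytotoxicity, read by CellTiter-Glo and resazurin assay, with a stated time of 72 h (a lower number here means that less compound is needed, a higher number that more compound is needed for the effect), compound 1 gives only > 26000 nM, which is a limit of the assay and not a number. Compound 2 likewise gives only > 26000 nM, again a limit of the assay. Going by the values given here, the single measured step, a step that the two limits leave unreadable from compound 1 to compound 2, therefore cannot be read: both ends sit at the limit of > 26000 nM in this assay, at which 2 of the 2 values shown sit. Where compound 2 stands is thus known only as a limit, with no further value to order it against.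

Compound 3 `COc1cccc(-c2ccc(C(=O)N(Cc3cccc(OCCCCCC(=O)O)c3)C(C)C)cc2)c1` differs from compound 2 by 3-methoxyphenyl in place of thiophen-3-yl on an aromatic carbon. Among the compounds with values here, no measured step covers this exchange, and the only measured step, from compound 1 to compound 2, gives no readable size, so the data hold no direction for the change. Given that compound 2 and compound 1 both return only the limit, compound 3 is expected to do the same, with an estimated value of 30000 nM and a range from 13000 nM to 70000 nM. The step that the limit leaves unreadable from compound 2 to compound 3 is expected to be none beyond the scatter, and most likely compound 3 is expected to be reported as a limit again.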

Compound 3, half-maximal effective concentration: > 20900 nM
Compound 3: only a limit was reported; the forecaster's own chance of this, stated with the estimate: 80%; the middle value lies beyond the limit too.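

In this assay compound 3 gives > 20900 nM, a limit of the assay and not a number. The steps from compound 1 and from compound 2 to compound 3 cannot be read, since all three values are limits. Still open, from the compounds shown here alone, is whether any of the three compounds has a numerical half-maximal effective concentration in this assay, and how the exchanged groups would then rank.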